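Swapping Chlorines for Fluorines on the Phenyl Ring

This account rests on a few compounds, and the source may have more. Where it says the series, first, only, none or still open, it means among the compounds named here.

Among the measured compounds shown here, in a functional assay on U-251 cells (Homo sapiens) (on this read-out lower numbers stand for stronger inhibition of growth and higher numbers for weaker inhibition of growth), compound 1 `O=S(=O)(/C=C/c1ccc(Cl)c(Cl)c1)Cc1ccc(Nc2ncnc3ccccc23)cc1` gives 11000 nM and holds the lower of the two numbers so far, while compound 2 `CC(C)(C)c1cc(/C=C/S(=O)(=O)Cc2ccc(Nc3ncnc4ccccc34)cc2)cc(C(C)(C)C)c1O` gives 38000 nM and lies beyond the scatter above it. Compound 3 `O=S(=O)(/C=C/c1ccc(F)cc1F)Cc1ccc(Nc2ncnc3ccccc23)cc1` differs from compound 1 in one place: 2,4-difluorophenyl in place of 3,4-dichlorophenyl on a double-bonded chain carbon bound to a double-bonded chain carbon on the shared core. For the measured compounds named here, no measured pair shows this swap, so the expected change in this assay is small and slightly toward a higher number, with a 1.5-fold higher number from compound 1 to compound 3 (0.16 log units; within the scatter) expected to stay within the scatter. For compound 3 the estimate is 16000 nM with an expected range from 6000 nM to 42000 nM in this measurement.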

Compound 3, concentration for 50% growth inhibition: > 100000 nM
Compound 3: only a limit was reported; the forecaster's own chance of this, stated with the estimate: 10%; middle value at least 6.2-fold (0.79 log units) from the limit.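

The value of compound 3 in this assay, > 100000 nM, is a limit of the assay and not a number. Even so, this place on the double-bonded chain carbon is sensitive to what the phenyl ring carries: 2,4-difluorophenyl in place of 3,4-dichlorophenyl gives an at least 9.0-fold higher number from compound 1 to compound 3 (0.95 log units; beyond the scatter). The two groups have the same heavy-atom count and the same ring, so those counts alone do not settle the outcome.

This swap changes both the halogen and where it sits on the ring, and the compounds shown do not separate the two. As far as these compounds go, how a phenyl ring carrying an amine or a carboxylic acid would behave here remains open.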